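This account rests on a few compounds, and the source may have more. Where it says the series, first, only, none or still open, it means among the compounds named here.

Two compounds of this series have numbers in an assay on isolated protein for inhibition of bone morphogenetic protein 1 (Homo sapiens); on this read-out lower numbers stand for stronger inhibition and higher numbers for weaker inhibition. Compound 1 `COc1ccc(S(=O)(=O)N(Cc2ccc(C(C)C)cc2)[C@H](C)C(=O)NO)cc1` gives 230 nM; compound 2 `COc1ccc(S(=O)(=O)N(Cc2ccc(Cl)c(Cl)c2)[C@H](C)C(=O)NO)cc1` gives 120 nM, the lower of the two numbers, but only by a 1.9-fold lower number from compound 1 to compound 2 (0.28 log units; within the scatter), within the scatter. Compound 3 `COc1ccc(S(=O)(=O)N(Cc2ccc(F)c(F)c2)[C@H](C)C(=O)NO)cc1` is unmeasured and carries 3,4-difluorophenyl in place of 3,4-dichlorophenyl on a saturated chain carbon bound to a sulfonamide nitrogen. For the measured compounds named here, the only measured step, from compound 1 to compound 2, also swaps one substituted phenyl for another and stays within the scatter, so no step beyond the scatter is expected here either, with the direction open. Compound 3 is expected near 200 nM, range 70 nM to 600 nM, an estimated step of a 1.7-fold higher number from compound 2 to compound 3 (0.22 log units; within the scatter).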

Compound 3, half-maximal inhibitory concentration: 76 nM
For compound 3 the middle estimate is 2.6-fold (0.42 log units) above the measured one; the measured number falls inside the stated range.
By their numbers in this assay, from the lowest: compounds 3, 2 and 1 (each within the scatter of the next, the first and the last beyond it).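

In this assay, 3,4-difluorophenyl for 3,4-dichlorophenyl gives a 1.6-fold lower number from compound 2 to compound 3 (0.20 log units; within the scatter), so this halogen exchange at this position does not separate the two compounds. Against 4-isopropylphenyl, the same position now shows its first step beyond the scatter, a 3.0-fold lower number from compound 1 to compound 3 (0.48 log units; beyond the scatter), though only a modest one. Nothing available bears on the origin of either step. Still open, on these data alone, is how a benzyl group carrying an amine or a carboxylic acid would read in this assay. Also open, as far as these compounds go, is whether a longer chain could replace the benzyl group.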